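A few compounds are considered here, and "the series" means these few. Any claim that something is new, unique, unknown or untested is made for them only; others in the source may bear on it.

Of the compounds shown here, three have been measured. Compound 1 `CC1(C)CN(NC(=S)Nc2cccc(C#N)c2)c2cc(Cl)ccc2O1` carries a 3-cyanophenyl on an amide-type nitrogen whose other neighbours are a thiocarbonyl carbon. In a functional assay on thoracic aorta (Rattus norvegicus) (on this read-out lower numbers stand for an effect already at smaller amounts and higher numbers for an effect only at larger amounts of compound), compound 1 gives only a limit of the assay, > 30000 nM. Compound 2 `CC1(C)CN(NC(=S)Nc2ccc(C#N)cc2)c2cc(Cl)ccc2O1` differs from it by 4-cyanophenyl in place of 3-cyanophenyl on an amide-type nitrogen. In this assay compound 2 likewise gives only a limit, > 30000 nM. The step that the two limits leave unreadable from compound 1 to compound 2 therefore cannot be read, because the limit of > 30000 nM in this assay, at which 2 of the 3 values shown sit, covers both values. For the measured compounds named here, compound 3 `CC1(C)CN(NC(=O)Nc2cccc(C#N)c2)c2cc(Cl)ccc2O1` is the one compound with a number: in this assay compound 3 gives 1900 nM. The difference between the core of compound 3 and the core of compound 1 is not broken down here. Compound 4 `CC1(C)CN(NC(=O)Nc2ccc(C#N)cc2)c2cc(Cl)ccc2O1` is not yet measured and differs from compound 3 by 4-cyanophenyl in place of 3-cyanophenyl on an amide-type nitrogen; here the amide-type nitrogen has a carbonyl carbon as its other neighbour, where in compound 1 it is a thiocarbonyl carbon, so this is the same kind of change, not the same one. Since the earlier step is unreadable, the expected step of a 1.6-fold higher number from compound 3 to compound 4 (0.20 log units; within the scatter) is taken as small and rests on compound 3 with 1900 nM. Compound 4 is estimated at 3000 nM in this assay, expected between 800 nM and 15000 nM.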

Compound 4, half-maximal effective concentration: 3700 nM
Compound 4: middle estimate off by 1.2-fold (0.09 log units), on the low side; low and high end bracket the measured number.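

In this assay the exchange of 3-cyanophenyl for 4-cyanophenyl on the amide-type nitrogen next to the carbonyl carbon gives a 1.9-fold higher number from compound 3 to compound 4 (0.29 log units; within the scatter), so on the core of compound 3 the two groups cannot be told apart. On the core of compound 1, where the neighbour is a thiocarbonyl carbon, the same kind of change cannot be read, because compound 1 and compound 2 each give only a limit of the assay: the limit of > 30000 nM in this assay, at which 2 of the 4 values shown sit. The series therefore offers a single readable step, which shows how the change behaves on one core and does not show that it carries over to the other.

What the compounds shown leave open is whether a phenyl ring bearing an amine or a carboxylic acid in place of the nitrile would read differently in this assay. Also open, going by these compounds, is how any such group would behave on the core of compound 1, whose two members give no number to compare with.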